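Adding Chloro Beside Trifluoromethyl on the Urea Aryl Group

The compounds below may be only part of what the source reports. "The series", "measured", "known", "first", "only" and "open" are said of these compounds alone.

Of the compounds shown here, three sharing one core have been tested in a functional assay on RXF 393 cells (Homo sapiens) for inhibition, read by sulforhodamine B assay, with a stated time of 48 h; a lower number here means that less compound is tolerated, a higher number that more compound is tolerated. Compound 3 `COc1cc(-c2nn(-c3cccc(NC(=O)Nc4cccc(C(F)(F)F)c4)c3)cc2-c2ccncc2)ccc1Cl` gives 4830 nM there. Compound 1 `COc1cc(-c2nn(-c3cccc(NC(=O)Nc4cc(C(F)(F)F)cc(C(F)(F)F)c4)c3)cc2-c2ccncc2)ccc1Cl` gives 4900 nM in this assay, and a 1.0-fold lower number from compound 1 to compound 3 (0.01 log units; within the scatter) shows the two sit within the scatter of each other. Compound 2 `COc1cc(-c2nn(-c3cccc(NC(=O)Nc4ccc(Cl)c(Cl)c4)c3)cc2-c2ccncc2)ccc1Cl` reaches only the limit of this assay, > 50000 nM, and the limit of > 50000 nM in this assay, at which 1 of the 3 values shown sits, marks that limit. Compound 3 therefore holds the lowest of the two real numbers, with compound 1 alongside it.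

Compound 4 `COc1cc(-c2nn(-c3cccc(NC(=O)Nc4ccc(Cl)c(C(F)(F)F)c4)c3)cc2-c2ccncc2)ccc1Cl` differs from compound 3 by chloro in place of hydrogen on an aromatic carbon. Among the measured compounds shown here, two measured steps bear on this. The step of a 1.0-fold lower number from compound 1 to compound 3 (0.01 log units; within the scatter) says that changing a substituent on this ring can leave the number unchanged, while an at least 10-fold lower number from compound 2 to compound 3 (1.01 log units; beyond the scatter) says that a chlorine-bearing ring at this position can push the number far up, beyond the scatter. Because compound 2 sits at > 50000 nM, a chloro entering next to the retained trifluoromethyl is expected to raise the number somewhat, so a 2.1-fold higher number from compound 3 to compound 4 (0.32 log units; beyond the scatter) is the estimated step. Compound 4 is accordingly estimated at 10000 nM, within 3000 nM to 50000 nM.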

Compound 4, concentration lethal to 50% of the cells: > 32500 nM
Compound 4: no number, only a limit; the forecaster's own chance of this, stated with the estimate: 30%; middle value at least 3.2-fold (0.51 log units) away from the limit.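

In this assay, chloro in place of hydrogen on this ring, ortho to the trifluoromethyl group, gives an at least 6.7-fold higher number from compound 3 to compound 4 (0.82 log units; beyond the scatter), so one added atom at this position moves the number beyond the scatter, whereas the change at the second trifluoromethyl on the same ring gave a 1.0-fold lower number from compound 1 to compound 3 (0.01 log units; within the scatter). Compound 4 gives no true number, only a limit: the limit of > 32500 nM in this assay, at which 1 of the 4 values shown sits. Compound 2, which also has chloro at this position, likewise gives only a limit: the limit of > 50000 nM in this assay, at which 1 of the 4 values shown sits.

The step between compound 2 and compound 4 cannot be read, so the compounds shown do not rank these two against each other. As far as these compounds go, it also remains open whether this rise is particular to chloro or would also appear with fluoro, methyl or an amine at the same position.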